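Removing one trifluoromethyl from the diaryl urea pyrazole series

The source may report more compounds than this note shows. Statements on the series, on what has been measured and on what is new or still open speak of the compounds shown alone.

Compound 1 `COc1cc(Cl)cc(-c2nn(-c3cccc(NC(=O)Nc4ccc(Cl)c(C(F)(F)F)c4)c3)cc2-c2ccncc2)c1` and compound 2 `COc1cc(Cl)cc(-c2nn(-c3cccc(NC(=O)Nc4cc(C(F)(F)F)cc(C(F)(F)F)c4)c3)cc2-c2ccncc2)c1` share a core and differ in the urea-bound aryl group. In a functional assay on MOLT-4 cells (Homo sapiens) for inhibition, read by sulforhodamine B assay, with a stated time of 48 h, tested at 10 uM (on this read-out lower numbers stand for a stronger effect and higher numbers for a weaker effect at the one concentration tested), compound 1 gives -9.68% and compound 2 gives -24.7%, the lowest of the two numbers, its nearest neighbour being compound 1 at a higher number, beyond the scatter. Compound 3 `COc1cc(Cl)cc(-c2nn(-c3cccc(NC(=O)Nc4cccc(C(F)(F)F)c4)c3)cc2-c2ccncc2)c1` arises from compound 2 by hydrogen in place of trifluoromethyl on an aromatic carbon. Within the data shown here, no step of this kind is measured, so the expected step is a moderate shift toward a higher, weaker number: a number 12.7 percentage points higher from compound 2 to compound 3 (beyond the scatter) is the expectation. Compound 3 is expected to give -12%, within -30% to 8%.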

Compound 3, a percentage reported as activity, at one concentration (the size of the read-out at that concentration, not a potency): -9.16%
Compound 3: middle estimate off by 2.8 percentage points, on the low side, within the range that was stated.
By their numbers in this assay, from the lowest: compound 2; then compounds 1 and 3 (each within the scatter of the next).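

In this assay, the trifluoromethyl on this aromatic carbon counts for something: replacing it with hydrogen gives a number 15.5 percentage points higher from compound 2 to compound 3 (beyond the scatter). A single trifluoromethyl with no chloro cannot be separated from the chloro-bearing analogue, with hydrogen in place of chloro giving a number 0.5 percentage points higher from compound 1 to compound 3 (within the scatter), so in this small set only the second trifluoromethyl gives a step beyond the scatter. Nothing available explains either step. As far as these compounds go, how an amine or a methoxy group on the same aromatic carbon would read remains open. A single concentration also leaves the potency of all these compounds open.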